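A few compounds are considered here, and "the series" means these few. Any claim that something is new, unique, unknown or untested is made for them only; others in the source may bear on it.

Of the compounds shown here, three built on one shared core have been tested in an ADME assay on HepG2 cells (Homo sapiens) for cytotoxicity, read by MTT assay, with a stated time of 48 h; a higher number here means a weaker inhibitor, a lower number a stronger inhibitor. Compound 1 `CCN(CC)CCCCN/C(=N\c1ccnc2cc(Cl)ccc12)C(C)C` gives 5.01 ug/mL in this assay, the higher of the two numbers obtained so far. Compound 3 `CN(C)CCCN/C(=N\c1ccnc2cc(Cl)ccc12)c1ccc(Cl)cc1` gives 1.93 ug/mL, a lower number, and the gap between these two lies beyond the usual scatter of the assay. For compound 2 `C/C(=N/c1ccnc2cc(Cl)ccc12)NC1CCN(C)CC1` the result is a limit rather than a number, > 30.3 ug/mL; this is the limit of > 30.3 ug/mL in this assay, at which 1 of the 3 values shown sits.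

Compound 4 `CC(C)/C(=N/c1ccnc2cc(Cl)ccc12)NCCCCN1CCCCC1` has not yet been measured. It differs from compound 1 in a single place: piperidin-1-yl in place of diethylamino on a saturated chain carbon, four bonds along the chain from an amine nitrogen. Among the compounds with values here, no measured pair in this set shows this particular change, so there is no direct step to lean on. The step from compound 1 to compound 4 in this assay is expected to be small, a 1.0-fold lower number from compound 1 to compound 4 (0.00 log units; within the scatter), with no clear direction beyond the scatter. Compound 4 is therefore estimated to give 5 ug/mL, most likely falling between 2.2 ug/mL and 12 ug/mL.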

Compound 4, half-maximal inhibitory concentration: 5.72 ug/mL
Estimate against measurement, compound 4: 1.1-fold (0.06 log units) below; low and high end bracket the measured number.
By their numbers in this assay, from the lowest: compound 3; then compounds 1 and 4 (each within the scatter of the next). At a limit, above all of these: compound 2.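

Piperidin-1-yl in place of diethylamino on a saturated chain carbon, four bonds along the chain from an amine nitrogen, gives the only step that can be read so far in this assay: a 1.1-fold higher number from compound 1 to compound 4 (0.06 log units; within the scatter). At this place, then, the open diethylamino group and the closed six-membered ring of piperidin-1-yl cannot be told apart by this read-out, even though the ring adds one heavy atom. Nothing measured here gives a cause for this result.

Going by these compounds, whether the same holds for a morpholine ring, a primary amine or a carboxylic acid in this place remains open. On these data alone, it is equally open whether the swap would read the same way on a shorter chain, or with a group other than the isopropyl of compound 1 on the shared core.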